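The source may report more compounds than this note shows. Statements on the series, on what has been measured and on what is new or still open speak of the compounds shown alone.

In a physicochemical assay for solubility, read by LC-MS, in phosphate buffer, with a stated time of 24 h, at pH 6.8 (on this read-out higher numbers stand for higher solubility and lower numbers for lower solubility), compound 1 `C[C@H](NC(=O)c1ncccn1)c1ccc(NC(=O)N2CC(c3cccnc3)C2)cc1` gives 930000 nM, while compound 2 `C[C@H](NC(=O)c1cccc(F)c1)c1ccc(NC(=O)N2CC(c3cncc(N)c3)C2)cc1` gives 17000 nM. Compound 2 therefore holds the lower of the two numbers, and its gap to compound 1 lies beyond the usual scatter of repeat measurements. Compound 3 `C[C@H](NC(=O)c1ncccn1)c1ccc(NC(=O)N2CC(c3cncc(N)c3)C2)cc1` differs from compound 2 in one place, on a carbonyl carbon, where pyrimidin-2-yl stands in place of 3-fluorophenyl (pyrimidin-2-yl in place of 3-fluorophenyl on a carbonyl carbon). Going by the values given here, no pair of measured compounds isolates this change, so the size of the step can only be judged indirectly. Compound 1 carries the same pyrimidin-2-yl on its carbonyl carbon and reads 930000 nM, although it also differs from compound 3 elsewhere. A rise beyond the scatter is therefore expected, with an estimated step of a 15-fold higher number from compound 2 to compound 3 (1.17 log units; beyond the scatter). The estimate for compound 3 is 250000 nM, with an expected range from 70000 nM to 800000 nM.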

Compound 3, solubility: 300000 nM
For compound 3 the middle estimate is 1.2-fold (0.08 log units) below the measured one, within the range that was stated.
By their numbers in this assay, from the lowest: compound 2; then compound 3; then compound 1.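

In this assay, the change from 3-fluorophenyl to pyrimidin-2-yl on a carbonyl carbon can now be read on its own, and it gives an 18-fold higher number from compound 2 to compound 3 (1.25 log units; beyond the scatter) with the rest of the structure held constant. Compound 3 also isolates a second change, amino in place of hydrogen on an aromatic carbon, which gives a 3.1-fold lower number from compound 1 to compound 3 (0.49 log units; beyond the scatter) and is a modest step in the opposite direction, so the large gain from pyrimidin-2-yl persists with the amino group present. Nothing shown here explains why either step occurs.

From the compounds shown here alone, it remains open how other groups on the carbonyl carbon, such as a carboxylic acid or a simple methyl, would read. Going by these compounds, it is also open whether the step from 3-fluorophenyl to pyrimidin-2-yl keeps its size when hydrogen stands in place of amino.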